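Adding a Second Fluorine to the Lowest-Exposure Urea

The source may report more compounds than this note shows. Statements on the series, on what has been measured and on what is new or still open speak of the compounds shown alone.

Three ureas sharing one core have been tested in an ADME assay on the whole organism for pharmacokinetics, with Rattus norvegicus as the target, at a dose of 1 mg/kg by the oral route; a higher number here means more compound in the circulation at the dose given, a lower number less compound in the circulation. Compound 1 `CC(C)CC1(O)CCN(C(=O)Nc2cc(Oc3ccc(F)cc3)cc(Oc3ccc(C4(C(=O)O)CC4)cc3)c2)CC1` gives 110 nM, compound 2 `CC(C)CC1(O)CCN(C(=O)Nc2cc(Oc3ccc(F)cc3)cc(Oc3ccc(C(=O)O)cc3)c2)CC1` gives 34.5 nM, and compound 3 `CC(C)CC1(O)CCN(C(=O)Nc2cc(Oc3ccc(F)cc3)cc(Oc3ccc(C(C)(C)C(=O)O)cc3)c2)CC1` gives 156 nM. Compound 2 thus stands lowest of the three: the step of a 3.2-fold lower number from compound 1 to compound 2 (0.50 log units; beyond the scatter) and the step of a 4.5-fold higher number from compound 2 to compound 3 (0.66 log units; beyond the scatter) both lie beyond the scatter, while the step of a 1.4-fold higher number from compound 1 to compound 3 (0.15 log units; within the scatter) does not.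

Compound 4 `CC(C)CC1(O)CCN(C(=O)Nc2cc(Oc3ccc(C(=O)O)cc3)cc(Oc3ccc(F)c(F)c3)c2)CC1` is not yet measured in this assay. It differs from compound 2 by a single change: fluoro in place of hydrogen on an aromatic carbon. Read one bond further out, the 4-fluorophenoxy group of compound 2 becomes a 3,4-difluorophenoxy group.

None of the three measured steps touches this part of the molecule; all of them alter the acid-bearing group on the other side of the core. So no measured step bears on the fluoro for hydrogen exchange, and there is no basis for expecting a shift in either direction beyond the scatter. The expectation is therefore a step from compound 2 to compound 4 of a 1.2-fold higher number from compound 2 to compound 4 (0.06 log units; within the scatter), within the scatter.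

Compound 4 is estimated to give 40 nM in this assay, in a range from 14 nM to 115 nM.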

Compound 4, maximal plasma concentration: 22.2 nM
For compound 4 the middle estimate is 1.8-fold (0.26 log units) above the measured one, within the range that was stated.
By their numbers in this assay, from the lowest: compounds 4 and 2 (each within the scatter of the next); then compounds 1 and 3 (each within the scatter of the next).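

In this assay, going from the 4-fluorophenoxy group to the 3,4-difluorophenoxy group gives a step (a 1.6-fold lower number from compound 2 to compound 4 (0.19 log units; within the scatter)) that lies within the usual scatter, so the read-out cannot tell this second fluorine from the hydrogen it replaces. For the compounds shown here, this is the first measured change on this side of the molecule, and it sets the position apart from the acid-bearing group on the other side, where a single change can reach beyond the scatter (a 4.5-fold higher number from compound 2 to compound 3 (0.66 log units; beyond the scatter)). No accompanying measurement helps to explain the plasma concentration seen for either compound.

The compounds shown leave open whether a different group on this aromatic carbon, such as a chlorine, a methoxy or a trifluoromethyl, would move the number beyond the scatter. They also leave open whether the same fluoro in place of hydrogen would read alike on compounds carrying the 1-carboxycyclopropyl or 1-carboxy-1-methylethyl group instead of the carboxy group.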